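The source may hold more compounds than are shown below. What is called first, only, known or untested is meant among the compounds shown, and "the series" means these compounds.

Three amide analogues on a shared core have been run in a functional assay on MGC-803 cells (Homo sapiens) for inhibition, read by MTT assay, with a stated time of 72 h; a higher number here means a weaker inhibitor, a lower number a stronger inhibitor. Compound 1 `O=C(CSc1nc(Nc2ccccc2)c2ccccc2n1)Nc1ccccc1Cl` gives 24800 nM, and compound 2 `O=C(CSc1nc(Nc2ccccc2)c2ccccc2n1)Nc1cccc([N+](=O)[O-])c1` gives 28100 nM. Compound 3 `CCc1ccc(NC(=O)CSc2nc(Nc3ccccc3)c3ccccc3n2)cc1` reaches only the limit of this assay, > 50000 nM, so it stands on a floor rather than a number. The steps of an at least 2.0-fold higher number from compound 1 to compound 3 (0.30 log units; that floor lies within the scatter) and an at least 1.7-fold higher number from compound 2 to compound 3 (0.25 log units; that floor lies within the scatter) both run toward that floor, which is the limit of > 50000 nM in this assay, at which 1 of the 3 values shown sits. Compound 4 `O=C(CSc1nc(Nc2ccccc2)c2ccccc2n1)Nc1ccc(F)c(Cl)c1` differs from compound 3 by 3-chloro-4-fluorophenyl in place of 4-ethylphenyl on an amide-type nitrogen, returning to a chlorine-substituted phenyl of the kind found in compound 1. A step back toward the numbers of compounds 1 and 2 is expected, of about an at least 1.6-fold lower number from compound 3 to compound 4 (0.22 log units; that floor lies within the scatter), though the floor leaves its true size open. Compound 4 is expected to give 30000 nM, within 12000 nM to 100000 nM.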

Compound 4, half-maximal inhibitory concentration: 20900 nM
For compound 4 the middle estimate is 1.4-fold (0.16 log units) above the measured one; the range from low to high includes it.
By their numbers in this assay, from the lowest: compounds 4, 1 and 2 (each within the scatter of the next). At a limit, above all of these: compound 3.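

In this assay, going by these compounds alone, 3-chloro-4-fluorophenyl in place of 4-ethylphenyl gives an at least 2.3-fold lower number from compound 3 to compound 4 (0.37 log units; beyond the scatter), the first step at this amide-type nitrogen to pass the scatter. The same group against the other two gives a 1.3-fold lower number from compound 2 to compound 4 (0.13 log units; within the scatter) and a 1.2-fold lower number from compound 1 to compound 4 (0.07 log units; within the scatter), so compounds 1, 2 and 4 stand level. Compound 3 remains at a limit, not a number: the limit of > 50000 nM in this assay, at which 1 of the 4 values shown sits.

Going by these compounds, the true size of the step from compound 3 stays open. Also open, on these data alone, is whether an amine or a carboxylic acid on the phenyl ring would move the number away from this level.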